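The source may report more compounds than this note shows. Statements on the series, on what has been measured and on what is new or still open speak of the compounds shown alone.

Measured compounds:
compound 1, `COc1cc(Cl)cc(-c2nn(-c3cccc(NC(=O)Nc4ccc(Cl)c(C(F)(F)F)c4)c3)cc2-c2ccncc2)c1`: 990 nM
compound 2, `COc1cc(Cl)cc(-c2nn(-c3cccc(NC(=O)Nc4cccc(C(F)(F)F)c4)c3)cc2-c2ccncc2)c1`: 1050 nM

Both numbers come from a functional assay on MDA-MB-468 cells (Homo sapiens) for inhibition, read by sulforhodamine B assay, with a stated time of 48 h; on this read-out higher numbers stand for weaker inhibition and lower numbers for stronger inhibition. Going by the values given here, compound 2 and compound 1 cannot be told apart there, since the only measured step, a 1.1-fold higher number from compound 1 to compound 2 (0.03 log units; within the scatter), lies within the scatter. Compound 3, `COc1cc(Cl)cc(-c2nn(-c3cccc(NC(=O)c4cccc(C(F)(F)F)c4)c3)cc2-c2ccncc2)c1`, has not been measured. It differs from compound 2 by 3-(trifluoromethyl)phenyl in place of (3-(trifluoromethyl)phenyl)amino on a carbonyl carbon: the carbonyl carbon keeps its amide-type nitrogen but loses the hydrogen-bond donor that the leaving group carried. Among the compounds with values here, no measured step touches this part of the molecule; the one step available, a 1.1-fold higher number from compound 1 to compound 2 (0.03 log units; within the scatter), concerns a chloro elsewhere and was flat, so it gives no guide to the size of the new change. Removing a hydrogen-bond donor from this linker is expected to cost some potency, so a step of a 2.4-fold higher number from compound 2 to compound 3 (0.38 log units; beyond the scatter) is estimated. Compound 3 is therefore expected to give about 2500 nM, in a range from 900 nM to 8000 nM.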

Compound 3, half-maximal inhibitory concentration: 4260 nM
Compound 3: the middle estimate sits 1.7-fold (0.23 log units) below what was measured; the measured number falls inside the stated range.
By their numbers in this assay, from the lowest: compounds 1 and 2 (each within the scatter of the next); then compound 3.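

Unlike the flat chloro step, exchanging (3-(trifluoromethyl)phenyl)amino for 3-(trifluoromethyl)phenyl on the carbonyl carbon weakens inhibition in this assay and gives a 4.1-fold higher number from compound 2 to compound 3 (0.61 log units; beyond the scatter) as its measured size. The same exchange made from the chloro-bearing urea gives a 4.3-fold higher number from compound 1 to compound 3 (0.63 log units; beyond the scatter) and points the same way, so in these compounds the group on the carbonyl carbon matters more than the chloro does. Nothing measured here explains this loss.

The compounds shown cannot separate the loss of the amide hydrogen from the loss of the nitrogen atom itself, a question that a urea with a methyl group on that nitrogen, or a methylene in its place, could address. As far as these compounds go, how an amine or a longer chain on the carbonyl carbon would read also remains open.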